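A Second Methoxy Group on a Weak Dioxygenase Inhibitor

The source may report more compounds than this note shows. Statements on the series, on what has been measured and on what is new or still open speak of the compounds shown alone.

Compound 1, `COc1cc(OC)cc(C2=C(Br)C(=O)c3ccc(C)cc32)c1`, in an assay on isolated protein for inhibition of alpha-ketoglutarate-dependent dioxygenase alkB homolog 3 (Homo sapiens), read by fluorescence, with stated times of 60 min and 15 min (on this read-out higher numbers stand for weaker inhibition and lower numbers for stronger inhibition), gives only the assay limit of > 50000 nM.
Compound 2, `COc1ccc(C2=C(Br)C(=O)c3ccc(C)cc32)cc1`, in this assay gives 43200 nM.

Going by the values given here, compound 2 thus holds the only measured number; compound 1 sits at the limit (the limit of > 50000 nM in this assay, at which 1 of the 2 values shown sits). Compound 3, `COc1ccc(C2=C(Br)C(=O)c3ccc(C)cc32)cc1OC`, differs from compound 2 by methoxy in place of hydrogen on an aromatic carbon. Among the compounds with values here, no measured step exists for this change. Compound 1, which also carries two methoxy groups, reached the limit, so a small step toward weaker inhibition, or none beyond the scatter, is expected. Compound 3 is estimated at 50000 nM, between 20000 nM and 120000 nM. The expected step is a 1.2-fold higher number from compound 2 to compound 3 (0.06 log units; within the scatter).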

Compound 3, half-maximal inhibitory concentration: > 50000 nM
Compound 3: no number, only a limit; the forecaster's own chance of this, stated with the estimate: 50%; the middle value lies on the limit itself.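

Methoxy in place of hydrogen, on an aromatic carbon ortho to a methoxy group, gives an at least 1.1-fold higher number from compound 2 to compound 3 (0.06 log units; that floor lies within the scatter). Compound 3 gives only a limit in this assay, not a number, so this change shows no sign of stronger inhibition, and its true size cannot be read. With this second methoxy group, the limit now covers most of the compounds shown: the limit of > 50000 nM in this assay, at which 2 of the 3 values shown sit.

From the compounds shown here alone, how much weaker compound 3 may be stays open. So does whether an amine or a carboxylic acid at this position would give a measurable number.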